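The source may hold more compounds than are shown below. What is called first, only, known or untested is meant among the compounds shown, and "the series" means these compounds.

Measured compounds

Compound 1, `C/C(=N\NC(N)=O)c1ccc2[nH]c(-c3ccc(Cl)cc3)nc2c1`: in an ADME assay on BHK-21 cells (Mesocricetus auratus) for cytotoxicity, read by MTT assay (on this read-out lower numbers stand for higher toxicity in this test and higher numbers for lower toxicity in this test), compound 1 gives > 100000 nM, which is a limit of the assay and not a number.
Compound 2, `C/C(=N\NC(N)=O)c1ccc2[nH]c(-c3ccc(C(F)(F)F)cc3)nc2c1`: in this assay compound 2 gives > 100000 nM, again a limit of the assay.
Compound 3, `C/C(=N\NC(N)=S)c1ccc2c(c1)nc(-c1ccc(Cl)cc1)n2C1CCCCC1`: in this assay compound 3 gives > 100000 nM, also a limit of the assay.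

The change from compound 1 to compound 2 is trifluoromethyl in place of chloro on an aromatic carbon. Its size in this assay is a step that the two limits leave unreadable from compound 1 to compound 2, since both ends sit at a limit. The difference between the core of compound 1 and the core of compound 3 is not broken down here. Compound 4, `C/C(=N\NC(N)=S)c1ccc2c(c1)nc(-c1ccc(C(F)(F)F)cc1)n2C1CCCCC1`, is not yet measured; it differs from compound 3 by trifluoromethyl in place of chloro on an aromatic carbon. The place wording agrees with that of the step from compound 1 to compound 2 up to one addition: for compound 3 to compound 4 the same difference, cut one bond further out, reads 4-chlorophenyl to 4-(trifluoromethyl)phenyl. It is therefore the same kind of change, made on a different core.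

All that is known of this change on the first core is that it did not bring either compound off the limit. The expectation for compound 4 rests on (the limit of > 100000 nM in this assay, at which 3 of the 3 values shown sit), where every value shown sits. Compound 4 is expected to stay at that limit, the expected step being a step that the limit leaves unreadable from compound 3 to compound 4. The estimate for compound 4 in this assay is 150000 nM, with a range from 100000 nM to 300000 nM.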

Compound 4, half-maximal cytotoxic concentration: > 100000 nM
Compound 4: a limit, no number; the forecaster's own chance of this, stated with the estimate: 85%; the middle value does not contradict the limit.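

In this assay compound 4 gives > 100000 nM, which is a limit of the assay and not a number. Compound 3 also sits at a limit, so no step can be read between compound 3 and compound 4. The values shown share one limit: the limit of > 100000 nM in this assay, at which 4 of the 4 values shown sit. Still open, going by these compounds, is how far trifluoromethyl in place of chloro moves the read-out in this assay on either core.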